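Swapping 4-Methoxyphenyl for Ethyl on the Shared Core

The source may report more compounds than this note shows. Statements on the series, on what has been measured and on what is new or still open speak of the compounds shown alone.

Compound 1 `O=C(/C=C/c1ccc(O)c(O)c1)N1CCN(c2ccccc2Cl)CC1` gives 1.82 ug/mL
Compound 2 `COc1cccc(N2CCN(C(=O)/C=C/c3ccc(O)c(O)c3)CC2)c1` gives 1.46 ug/mL
Compound 3 `COc1ccc(N2CCN(C(=O)/C=C/c3ccc(O)c(O)c3)CC2)cc1` gives 1.21 ug/mL

All three values come from a functional assay on B16-F10 cells (Mus musculus) for antiproliferative activity, read by MTT assay, with a stated time of 48 h; on this read-out lower numbers stand for stronger inhibition and higher numbers for weaker inhibition. Compound 3 stands level with the other two compounds, as shown by a 1.2-fold lower number from compound 2 to compound 3 (0.08 log units; within the scatter) and a 1.5-fold lower number from compound 1 to compound 3 (0.18 log units; within the scatter). Compound 4 `CCN1CCN(C(=O)/C=C/c2ccc(O)c(O)c2)CC1` carries ethyl in place of 4-methoxyphenyl on an amine nitrogen in a ring.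

The measured steps at this place are a 1.2-fold lower number from compound 1 to compound 2 (0.10 log units; within the scatter), a 1.5-fold lower number from compound 1 to compound 3 (0.18 log units; within the scatter) and a 1.2-fold lower number from compound 2 to compound 3 (0.08 log units; within the scatter). Each exchanges one substituted phenyl group for another, so none of them shows what happens when the aromatic ring is lost. Among the measured compounds shown here, they therefore offer no direct precedent, and any forecast is uncertain. A modest move towards a higher number in this assay is expected, meaning somewhat weaker inhibition. The expected change is a 2.1-fold higher number from compound 3 to compound 4 (0.32 log units; beyond the scatter). For compound 4 the estimated value is 2.5 ug/mL, with an expected range of 1 ug/mL to 6.5 ug/mL.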

Compound 4, half-maximal inhibitory concentration: 6.44 ug/mL
For compound 4 the middle estimate is 2.6-fold (0.41 log units) below the measured one, within the range that was stated.
By their numbers in this assay, from the lowest: compounds 3, 2 and 1 (each within the scatter of the next); then compound 4.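

Among the compounds shown here, replacing a substituted phenyl group with ethyl on the amine nitrogen is the first change at this position to go beyond the scatter in this assay (a 5.3-fold higher number from compound 3 to compound 4 (0.73 log units; beyond the scatter)), and the same holds against the other two phenyl compounds (a 4.4-fold higher number from compound 2 to compound 4 (0.64 log units; beyond the scatter); a 3.5-fold higher number from compound 1 to compound 4 (0.55 log units; beyond the scatter)). Compounds 1, 2 and 3 remain within the scatter of one another, so among these four compounds the clear separation lies between ethyl and the phenyl-bearing groups rather than among the phenyl substituents. Nothing in the data shown gives a reason for this shift.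

Ethyl differs from the phenyl groups both in lacking a ring and in having fewer heavy atoms, so these compounds do not separate those two changes. A cyclohexyl group, a benzyl group or a longer alkyl chain on the same nitrogen would bear on that question.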